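The source may report more compounds than this note shows. Statements on the series, on what has been measured and on what is new or still open speak of the compounds shown alone.

Three compounds have so far been measured in an assay for displacement of a labelled ligand from DNA repair protein REV1 (Homo sapiens), read by fluorescence polarization, with a stated time of 1 h; on this read-out lower numbers stand for stronger inhibition and higher numbers for weaker inhibition:

Compound 1, `CC(=O)N1CCC(C(=O)Nc2sc3c(c2C(=O)NC2CC2)CCC(C)C3)CC1`: 4600 nM
Compound 2, `CCc1ccc(NC(=O)CN2CCN(c3ccc(F)cc3)CC2)cc1`: 6900 nM
Compound 3, `CCCc1cc(C(=O)OCC)c(NC(=O)C2CCN(C(C)=O)CC2)s1`: 11600 nM

Compound 1 gives the lowest of these three numbers. Its gap to compound 2 lies within the usual scatter of repeated measurements, so the two cannot be ranked against each other; its gap to compound 3 lies beyond the scatter, so compound 1 does stand lower than compound 3. No two of the measured compounds differ in only one place, so no single structural change has yet been tied to a change in number.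

Compound 4, `CC(=O)N1CCC(C(=O)Nc2sc3c(c2C(N)=O)CCC(C)C3)CC1`, has not been measured. It differs from compound 1 in one place: hydrogen in place of cyclopropyl on an amide-type nitrogen. In words, a hydrogen takes the place of cyclopropyl on an amide-type nitrogen, so the cyclopropylcarbamoyl group becomes a carbamoyl group, and the shared core is otherwise untouched.

Among the compounds with values here, with no comparable step among the measured compounds, the size and direction of this change can only be estimated. Removing the cyclopropyl is a small change, and the expected step in this assay is modest, most likely a small shift toward weaker binding or none beyond the scatter. The step from compound 1 to compound 4 is expected to be a 1.4-fold higher number from compound 1 to compound 4 (0.15 log units; within the scatter). Compound 4 is therefore estimated at 6500 nM, with a plausible range from 2500 nM to 17000 nM.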

Compound 4, inhibition constant: 15700 nM
Compound 4: middle estimate off by 2.4-fold (0.38 log units), on the low side, and the stated range covers the measured number.
By their numbers in this assay, from the lowest: compounds 1, 2, 3 and 4 (each within the scatter of the next, the first and the last beyond it).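

Within the data shown here, this is the only step so far that ties a change in number to a single structural change: in this assay, putting hydrogen in place of cyclopropyl on the amide-type nitrogen, which turns cyclopropylcarbamoyl into carbamoyl, gives a 3.4-fold higher number from compound 1 to compound 4 (0.53 log units; beyond the scatter) and lies beyond the usual scatter. With the shared core otherwise untouched, this shows that the number responds to what sits on this nitrogen, and that the compound carrying cyclopropyl there stands lower than the one carrying only hydrogen. Nothing measured on these compounds explains why the number moves this way, so the step stands as an observation without a known cause.

From the compounds shown here alone, with only hydrogen and cyclopropyl seen on this nitrogen, it remains open whether methyl, a larger ring such as cyclohexyl, or a longer chain such as butyl would match compound 1, go lower or go higher. One step on one core also leaves open whether the same exchange would move the number in the same direction and by a similar amount on a different core.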